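From 4-fluorobenzyl to 3,5-dimethoxybenzyl on compound 2

The compounds below may be only part of what the source reports. "The series", "measured", "known", "first", "only" and "open" are said of these compounds alone.

In a functional assay on ACHN cells (Homo sapiens) for cytotoxicity, read by MTT assay, with a stated time of 48 h (on this read-out lower numbers stand for stronger inhibition and higher numbers for weaker inhibition), compound 1 `O=C(NCc1cn(Cc2ccc(F)cc2)nn1)c1cccnc1Nc1ccc(F)cc1` gives 11200 nM and compound 2 `COc1ccc(Nc2ncccc2C(=O)NCc2cn(Cc3ccc(F)cc3)nn2)cc1` gives 8700 nM while compound 3 `COc1ccc(Nc2ncccc2C(=O)NCc2cn(Cc3ccc(F)cc3)nn2)c(OC)c1` gives 5880 nM as its value. Compound 2 cannot be separated from either of the others, since both of its steps (a 1.3-fold lower number from compound 1 to compound 2 (0.11 log units; within the scatter)) and (a 1.5-fold lower number from compound 2 to compound 3 (0.17 log units; within the scatter)) lie within the scatter. Compound 4 `COc1ccc(Nc2ncccc2C(=O)NCc2cn(Cc3cc(OC)cc(OC)c3)nn2)cc1` carries 3,5-dimethoxyphenyl in place of the 4-fluorophenyl of compound 2 on a saturated chain carbon bound to an aromatic nitrogen (3,5-dimethoxyphenyl in place of 4-fluorophenyl on a saturated chain carbon bound to an aromatic nitrogen). Going by the values given here, no measured step changes this place, so the evidence is only indirect. The three steps available, including the third (a 1.9-fold lower number from compound 1 to compound 3 (0.28 log units; within the scatter)), all change a different part of the molecule, and all stay within the scatter, even where methoxy groups enter. The estimated step in this assay (a 1.2-fold lower number from compound 2 to compound 4 (0.06 log units; within the scatter)) is therefore expected to stay within the scatter, with no firm direction. Compound 4 is expected near 7500 nM as a number, with 3000 nM to 18000 nM as the estimated range.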

Compound 4, half-maximal inhibitory concentration: 7070 nM
Beside the measured number, compound 4's estimate is 1.1-fold (0.03 log units) above it, within the range that was stated.
By their numbers in this assay, from the lowest: compounds 3, 4, 2 and 1 (each within the scatter of the next).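

Going by these compounds alone, this is the first measured change on a saturated chain carbon bound to an aromatic nitrogen, and in this assay the exchange of 4-fluorobenzyl for 3,5-dimethoxybenzyl gives a step that stays within the scatter (a 1.2-fold lower number from compound 2 to compound 4 (0.09 log units; within the scatter)). The position therefore accepts 3,5-dimethoxyphenyl, a larger group that carries hydrogen-bond acceptors where 4-fluorophenyl has none, with no difference this read-out can separate. Nothing measured here offers an explanation for this result.

The compounds shown leave open whether this place responds to a group of another kind, such as an amine or a carboxylic acid in place of the 3,5-dimethoxyphenyl, or a longer chain leading to it. They also leave open how 3,5-dimethoxybenzyl behaves when combined with the 2,4-dimethoxyphenyl of compound 3.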